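The source may hold more compounds than are shown below. What is called first, only, known or untested is meant among the compounds shown, and "the series" means these compounds.

In an ADME assay for permeability, using PAMPA, at pH 7.4 (on this read-out lower numbers stand for lower permeability and higher numbers for higher permeability), two compounds sharing one core have been measured so far. Compound 1 `Cc1ccc(NC(=O)Nc2cc(C)nc3ccccc23)cc1` gives 669 10^-6 cm/s and compound 2 `COC(=O)c1ccc(NC(=O)Nc2cc(C)nc3ccccc23)cc1` gives 448 10^-6 cm/s. These two values lie within the scatter of each other, so compound 2 cannot be told apart from compound 1 on this read-out. Compound 3 `Cc1cc(NC(=O)Nc2ccc(C(F)(F)F)cc2)c2ccccc2n1` keeps the shared core and differs from compound 2 in one group: trifluoromethyl in place of methoxycarbonyl on an aromatic carbon. Here trifluoromethyl stands in place of methoxycarbonyl on an aromatic carbon. Among the compounds with values here, the one measured step that bears on this change is a 1.5-fold lower number from compound 1 to compound 2 (0.17 log units; within the scatter), which exchanged methyl for methoxycarbonyl on an aromatic carbon. Within the data shown here, no measured compound carries trifluoromethyl, so this guidance is thin. No change beyond the scatter is expected, and the estimated step is a 1.2-fold higher number from compound 2 to compound 3 (0.09 log units; within the scatter). The expected value for compound 3 is 550 10^-6 cm/s, with an estimated range of 250 10^-6 cm/s to 1100 10^-6 cm/s.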

Compound 3, apparent permeability: 2 10^-6 cm/s
Compound 3: the middle estimate sits 280-fold (2.44 log units) above what was measured; measured number below the stated range.
By their numbers in this assay, from the lowest: compound 3; then compounds 2 and 1 (each within the scatter of the next).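

In this assay the step of a 220-fold lower number from compound 2 to compound 3 (2.35 log units; beyond the scatter) for trifluoromethyl in place of methoxycarbonyl and the step of a 330-fold lower number from compound 1 to compound 3 (2.52 log units; beyond the scatter) for trifluoromethyl in place of methyl show that the group on this aromatic carbon can move the read-out far beyond the scatter. The earlier pair showed no such thing: methyl and methoxycarbonyl lie within the scatter of each other, while trifluoromethyl stands well apart from both, even though it has the same count of heavy atoms as methoxycarbonyl. Nothing at hand accounts for this sharp separation.

As far as these compounds go, whether the fall belongs to trifluoromethyl alone or would also follow a chlorine atom, a nitrile or an amine on this carbon stays open. Also open, from the compounds shown here alone, is whether trifluoromethyl would give the same fall on another carbon of this ring.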